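Shortening the Side Chain on a Uracil Nucleoside

The compounds below may be only part of what the source reports. "The series", "measured", "known", "first", "only" and "open" are said of these compounds alone.

Measured so far:
compound 1, `CCCCCCCCc1cn([C@H]2C[C@H](O)[C@@H](CO)O2)c(=O)[nH]c1=O`: 72 ug/mL
compound 2, `CCc1cn([C@H]2C[C@@H]3OP(=O)(O)OC[C@H]3O2)c(=O)[nH]c1=O`: > 500 ug/mL

Of the compounds shown here, two have been measured in a functional assay on L1210 cells (Mus musculus); a lower number here means a stronger inhibitor, a higher number a weaker inhibitor. Within the data shown here, compound 1 gives 72 ug/mL, and this is the only actual number in the set. For compound 2 the read-out is a limit of the assay, > 500 ug/mL. For compound 2 that value is the limit of > 500 ug/mL in this assay, at which 1 of the 2 values shown sits. Compound 1 therefore stands alone as the one measured point with a number.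

Compound 3, `CCCCCCc1cn([C@H]2C[C@H](O)[C@@H](CO)O2)c(=O)[nH]c1=O`, has not yet been measured. It differs from compound 1 by hydrogen in place of ethyl on a saturated chain carbon, six bonds along the chain from an aromatic carbon. Among the measured compounds shown here, no measured pair differs in just one place, so the size of this step has no measured anchor. In this assay the expected step is a 2.2-fold higher number from compound 1 to compound 3 (0.35 log units; beyond the scatter), a weakening that may exceed the usual scatter. Compound 3 is estimated at 160 ug/mL, with a range from 45 ug/mL to 500 ug/mL.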

Compound 3, concentration for 50% inhibition: 195 ug/mL
The estimate for compound 3 lay 1.2-fold (0.09 log units) below the measured number, within the range that was stated.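

Among these compounds, replacing ethyl with hydrogen on a saturated chain carbon, six bonds along the chain from an aromatic carbon, gives a 2.7-fold higher number from compound 1 to compound 3 (0.43 log units; beyond the scatter) in this assay, and this is the first measured step in the set. It shows that this part of the side chain matters: losing two carbons weakens the inhibitor by more than the usual scatter, although compound 3 still gives a real number, 195 ug/mL, and not a limit. Nothing measured here explains why this change weakens inhibition.

Two chain lengths on this core cannot show whether the trend is steady or where it stops, so a longer chain such as decyl or a shorter one such as butyl would test it. From the compounds shown here alone, whether an amine or a carboxylic acid on this chain would be tolerated also remains open.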